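Aryl substituent swap on the shared core

This account rests on a few compounds, and the source may have more. Where it says the series, first, only, none or still open, it means among the compounds named here.

Measured so far:
- compound 1 `CC#CC(CC(=O)O)c1ccc(OCc2ccc3nc(-c4ccc(C(F)(F)F)cc4)cn3c2)cc1`: 558 nM
- compound 2 `CC#CC(CC(=O)O)c1ccc(OCc2ccn3cc(-c4ccc(C)cc4C)nc3c2)cc1`: 503 nM

In an assay on isolated protein for agonist activity at Free fatty acid receptor 1 (Homo sapiens) (on this read-out lower numbers stand for an effect already at smaller amounts and higher numbers for an effect only at larger amounts of compound), compound 1 gives 558 nM and compound 2 gives 503 nM; these two numbers lie within the scatter of each other, so neither stands apart. Compound 1 holds the higher of the two numbers by a margin that means nothing.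

Compound 3 `CC#CC(CC(=O)O)c1ccc(OCc2ccc3nc(-c4ccc(OC)cc4)cn3c2)cc1` has not yet been measured in this assay. Relative to compound 1 the change is methoxy in place of trifluoromethyl on an aromatic carbon. Among the compounds with values here, no measured pair shows this kind of change, so the size of the step has no precedent here. The expectation is a step from compound 1 to compound 3 of a 1.2-fold higher number from compound 1 to compound 3 (0.07 log units; within the scatter), that is, nothing clearly beyond the scatter in either direction. Compound 3 is therefore estimated at 650 nM, with a range from 200 nM to 2000 nM.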

Compound 3, half-maximal effective concentration: 47 nM
The estimate for compound 3 lay 14-fold (1.14 log units) above the measured number; the measured number lies below the stated range.
By their numbers in this assay, from the lowest: compound 3; then compounds 2 and 1 (each within the scatter of the next).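

In this assay, methoxy in place of trifluoromethyl on an aromatic carbon, para to a large group, gives a 12-fold lower number from compound 1 to compound 3 (1.07 log units; beyond the scatter) on an otherwise unchanged structure. This position is therefore sensitive to its substituent, which could not be read from compound 1 and compound 2, as they differ in more than one place. Nothing available indicates what about this exchange accounts for the step.

As far as these compounds go, it remains open whether the step is specific to methoxy or would also appear with other groups at this place, such as an amine, a hydroxy group or a longer ethoxy chain. From the compounds shown here alone, it is also open whether the same exchange would produce a step of similar size on the core of compound 2.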